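This account rests on a few compounds, and the source may have more. Where it says the series, first, only, none or still open, it means among the compounds named here.

Compound 1 `COc1ccc(S(=O)(=O)c2cnc3cc(F)ccc3c2N2CCC(C)CC2)cc1` gives 90% in an assay on isolated protein for displacement of a labelled ligand from metabotropic glutamate receptor 5 (Homo sapiens), with a stated time of 60 min, tested at 1 uM; a higher number here means more inhibition at the concentration tested (going by the name of the read-out), a lower number less inhibition. Compound 2 `CC1CCN(c2c(S(=O)(=O)c3ccc(C#N)cc3)cnc3cc(F)ccc23)CC1` gives 83% in this assay. Going by the values given here, the only change from compound 1 to compound 2 is cyano in place of methoxy on an aromatic carbon and the step it made was a number 7 percentage points lower from compound 1 to compound 2 (within the scatter), so the two values do not separate from each other.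

Compound 3 `COc1cccc(S(=O)(=O)c2cnc3cc(Cl)ccc3c2N2CCC(C)CC2)c1` gives 93% in this assay. Compound 3 and compound 1 differ in more than one place, and the difference between the two cores is not broken down here; their values lie within the scatter of one another, and so do those of compound 3 and compound 2.

Compound 4 `CC1CCN(c2c(S(=O)(=O)c3cccc(C#N)c3)cnc3cc(Cl)ccc23)CC1` has not yet been measured. It arises from compound 3 by cyano in place of methoxy on an aromatic carbon. Among the compounds with values here, this is the same kind of change as the one from compound 1 to compound 2, but not the same: in compound 2 the group sits para to a large group, whereas in compound 4 it sits meta to a large group, and it is made on the core of compound 3 rather than that of compound 1.

Because the earlier step of this kind was a number 7 percentage points lower from compound 1 to compound 2 (within the scatter), the step from compound 3 to compound 4 is expected to be small, namely a number 6 percentage points lower from compound 3 to compound 4 (within the scatter). On that basis compound 4 is estimated to give 87% in this assay, with the likely range running from 72% to 96%.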

Compound 4, a percentage reported as inhibition, at one concentration (the size of the read-out at that concentration, not a potency): 94%
The estimate for compound 4 lay 7 percentage points below the measured number; low and high end bracket the measured number.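

Going by these compounds alone, on the core of compound 3, putting cyano in place of methoxy gave a number 1 percentage points higher from compound 3 to compound 4 (within the scatter) in this assay, so this replacement produced no step that can be told from the scatter on this core. Set beside the same replacement on the core of compound 1, the new step does not separate from the earlier one, and in this pair of cores the change carries over without a visible difference: the same change on two cores in this assay, a number 7 percentage points lower (within the scatter) from compound 1 to compound 2 and a number 1 percentage points higher (within the scatter) from compound 3 to compound 4, 8 percentage points apart, within the scatter of two such steps This does not show that the change is neutral in general or that the core has no influence on it, since there are only two pairs, they differ in where the group sits as well as in the core, and the read-out is a size at one concentration rather than a potency, which could leave differences between the compounds unseen.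

From the compounds shown here alone, what happens on these cores when an amine, a carboxylic acid or a longer chain such as propoxy stands in place of methoxy remains open. Going by these compounds, it is also open whether compound 3 and compound 4 would separate from each other at a lower concentration.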